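Replacing a propargyl ester with a dimethoxybenzyl ester

A few compounds are considered here, and "the series" means these few. Any claim that something is new, unique, unknown or untested is made for them only; others in the source may bear on it.

These compounds share one core, to which a sugar and two ester groups are attached. Compound 1 `C/C=C1/[C@H](O[C@@H]2O[C@H](COC(C)=O)[C@@H](OC(C)=O)[C@H](OC(C)=O)[C@H]2OC(C)=O)OC=C(C(=O)OC)[C@H]1CC(=O)OCCC` carries an acetylated sugar, and in a functional assay on SK-BR-3 cells (Homo sapiens) for antiproliferative activity, read by MTT assay, with a stated time of 72 h (a lower number here means a stronger inhibitor, a higher number a weaker inhibitor), compound 1 gives 6600 nM. Compound 3 `C/C=C1/[C@H](O[C@@H]2O[C@H](COC(C)=O)[C@@H](OC(C)=O)[C@H](OC(C)=O)[C@H]2OC(C)=O)OC=C(C(=O)OC)[C@H]1CC(=O)OCC` has the same acetylated sugar but a shorter ester chain. In this assay compound 3 reports only a limit, > 15000 nM. The change from compound 1 to compound 3 is therefore an at least 2.2-fold higher number from compound 1 to compound 3 (0.35 log units; beyond the scatter), and in that pair the larger ester group went with the stronger number.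

Compound 2 `C#CCOC(=O)C[C@@H]1C(C(=O)OC)=CO[C@@H](O[C@@H]2O[C@H](CO)[C@@H](O)[C@H](O)[C@H]2O)/C1=C/C` has a free sugar and a propargyl ester. In this assay compound 2 also reports only a limit, > 15000 nM. Compound 2 thus stands at the weak end of what has been measured, sharing the limit of > 15000 nM in this assay, at which 2 of the 3 values shown sit, with compound 3, while only compound 1 gives an actual number.

Compound 4 `C/C=C1/[C@H](O[C@@H]2O[C@H](CO)[C@@H](O)[C@H](O)[C@H]2O)OC=C(C(=O)OC)[C@H]1CC(=O)OCc1ccc(OC)c(OC)c1` differs from compound 2 by 3,4-dimethoxyphenyl in place of ethynyl on a saturated chain carbon bound to an oxygen next to a carbonyl group. Among the compounds with values here, the only measured step that bears on this is the one from compound 1 to compound 3, where enlarging the ester group helped, so compound 4 is expected to move in the stronger direction by an at least 2.1-fold lower number from compound 2 to compound 4 (0.33 log units; beyond the scatter). Compound 4 is estimated at 7000 nM, within a range from 1500 nM to 20000 nM.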

Compound 4, half-maximal inhibitory concentration: > 15000 nM
Compound 4: a limit, no number; the forecaster's own chance of this, stated with the estimate: 35%; middle value at least 2.1-fold (0.33 log units) from the limit.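

In this assay compound 4 gives only a limit, > 15000 nM. Compound 2 also gives only a limit, > 15000 nM. The step between compound 2 and compound 4 therefore cannot be read. The compounds shown leave open whether going from propargyl to 3,4-dimethoxybenzyl on the free-sugar compounds changes the antiproliferative activity at all.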